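This account rests on a few compounds, and the source may have more. Where it says the series, first, only, none or still open, it means among the compounds named here.

Within the data shown here, compound 1 `CCc1ccc(-c2nc(N)c3cc(Cc4ccccc4)sc3n2)o1` is the only member of the series with a definite number in a functional assay on CHO-K1 cells for antagonist activity at adenosine receptor A1 (Homo sapiens), read by a beta-galactosidase reporter and cAMP accumulation, with stated times of 15 min and 6 h (a lower number here means a stronger inhibitor, a higher number a weaker inhibitor), where compound 1 gives 223 nM. Compound 2 `C=C(c1ccccc1)c1cc2c(N)nc(-c3nc(C)cs3)nc2s1` is reported in this assay only as the limit > 594 nM, a boundary of the measurement rather than a number. That boundary, (the limit of > 594 nM in this assay, at which 1 of the 2 values shown sits), holds one of the two values shown. Among the measured compounds shown here, no pair of measured compounds differs in a single place, so no measured step is available, and compound 1 stands alone as the point of reference for anything new.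

Compound 3 `COc1cccc(-c2nc(N)c3cc(Cc4ccccc4)sc3n2)c1` has not yet been measured in this assay. It differs from compound 1 by 3-methoxyphenyl in place of 5-ethylfuran-2-yl on an aromatic carbon. For the measured compounds named here, with no measured step of this kind at hand, the expectation rests on compound 1 alone. The step from compound 1 to compound 3 is estimated as a 1.4-fold higher number from compound 1 to compound 3 (0.16 log units; within the scatter), a modest loss that may well lie within the scatter. Compound 3 is therefore expected to give about 320 nM in this assay, with a range from 90 nM to 1200 nM. A reading that ends in a limit, as for compound 2, cannot be excluded.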

Compound 3, inhibition constant: 266 nM
For compound 3 the middle estimate is 1.2-fold (0.08 log units) above the measured one, within the range that was stated.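

The series now has its first measured step at a single place, the aromatic carbon between two ring nitrogen atoms, and in this assay that step reads a 1.2-fold higher number from compound 1 to compound 3 (0.08 log units; within the scatter) for 3-methoxyphenyl in place of 5-ethylfuran-2-yl. At this position, then, a five-membered aromatic ring with 1 hetero atom and a six-membered aromatic ring of carbon only cannot be told apart in this read-out, although the ring size and the oxygen's setting both differ; this holds for this one pair on the core of compound 1 and is no rule for the series. Nothing at hand gives a cause for this result, and the single limit in the set, which belongs to compound 2, bears on no step.

Open, as far as these compounds go, is whether this place tolerates groups of a different kind, such as a saturated amine like morpholine or a carboxylic acid, as it tolerates these two aromatic rings. Also open, from the compounds shown here alone, is whether a longer chain in place of the ethyl on the furan, or a hydroxy in place of the methoxy on the phenyl, would move the number beyond the scatter.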